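Notes on an acetamido-for-methyl exchange in a pyrimidine series

A few compounds are considered here, and "the series" means these few. Any claim that something is new, unique, unknown or untested is made for them only; others in the source may bear on it.

Measured so far:
- compound 1 `CC(C)(C)C1CCc2nc(N)ncc2C1`: 41%
- compound 2 `CN1CCc2nc(N)ncc2C1`: < 5%
- compound 3 `Cc1ncc(-c2ccccc2)c(C(C)(C)C)n1`: 22%

In a functional assay on the whole organism for inhibition, with Rattus norvegicus as the target, with stated times of 1 h and 3.5 h, at a dose of 100 mg/kg by the oral route (on this read-out higher numbers stand for more inhibition at the one dose given (going by the name of the read-out) and lower numbers for less inhibition), compound 1 gives 41%. For compound 2 the result in this assay is only a limit of the assay, < 5%, and (the limit of < 5% in this assay, at which 1 of the 3 values shown sits). Compound 3 gives 22% in this assay, the lowest of the two numbers shown; compound 1 stands higher, a gap beyond the scatter. Among the compounds with values here, no two measured compounds differ in one place, so no single step has been measured.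

Compound 4 `CC(=O)Nc1ncc(-c2ccccc2)c(C(C)(C)C)n1` is not yet measured. It differs from compound 3 by acetamido in place of methyl on an aromatic carbon. As far as these compounds go, the other compounds carry an amino group at the corresponding position of their core, but none shares the core of compound 3, so the change is untested here.

Compound 4 is expected to give about 25% in this assay, within 5% to 50%. That estimate means a step of a number 3 percentage points higher from compound 3 to compound 4 (within the scatter), not clearly beyond the scatter in either direction.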

Compound 4, a percentage reported as inhibition, in the whole organism at one dose (the size of the read-out at that dose, not a potency): 29%
Beside the measured number, compound 4's estimate is 4 percentage points below it; the measured number falls inside the stated range.
By their numbers in this assay, from the lowest: compounds 3 and 4 (each within the scatter of the next); then compound 1. At a limit, below all of these: compound 2.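

In this assay, acetamido in place of methyl on the aromatic carbon between two ring nitrogen atoms gives a number 7 percentage points higher from compound 3 to compound 4 (within the scatter). Within the data shown here, this position on the shared core therefore accepts a larger group, one carrying a hydrogen-bond donor and acceptor, with no change in the read-out beyond the scatter at the one dose given, which the earlier compounds, lacking any single-place step, could not show. Nothing available bears on why the exchange leaves the read-out within the scatter.

Among these compounds, the result covers only this one exchange, so it remains open whether a free amine, a carboxylic acid or a longer acyl chain such as butyramido at this position would stay within the scatter of the methyl compound. A single-dose read-out also leaves open whether the two compounds would match across other doses.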